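Working notes on compounds 1 to 4: the benzyl-to-methyl step

The source may hold more compounds than are shown below. What is called first, only, known or untested is meant among the compounds shown, and "the series" means these compounds.

compound 1, `CC(C)C[C@]1(O)NC(=O)[C@]2(OC(Cc3ccccc3)=CC2=O)[C@H]1O`: > 100000 nM
compound 2, `CC(C)CC(=O)[C@@H]1O[C@@]12C(=O)C=C(Cc1ccccc1)NC2=O`: > 100000 nM
compound 3, `CC1=CC(=O)C2(OC2C(=O)CC(C)C)C(=O)N1`: 32100 nM

Of the compounds shown here, three have been tested in a functional assay on A549 cells (Homo sapiens) for cytotoxicity, read by WST assay, with a stated time of 48 h; on this read-out lower numbers stand for stronger inhibition and higher numbers for weaker inhibition. For compound 1 the result is a limit of the assay, not a number, namely > 100000 nM. Compound 2 likewise sits at a limit of the assay. For the measured compounds named here, compound 3 is the only member with a measured number, 32100 nM. Compound 1 therefore stands at the weak end of what has been seen, together with compound 2, and the picture is summarised by the limit of > 100000 nM in this assay, at which 2 of the 3 values shown sit.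

The next compound, compound 4 `CC1=CC(=O)[C@]2(O1)C(=O)N[C@@](O)(CC(C)C)[C@@H]2O`, differs from compound 1 by hydrogen in place of phenyl on a saturated chain carbon bound to a double-bonded ring carbon. Going by the values given here, compound 3 carries a methyl at the corresponding position, but its core is otherwise not that of compound 1, so no measured step exists for this change. Given that compound 1 gives only a limit at > 100000 nM, the step is expected to be small, none beyond the scatter, with a real chance of another limit: a number no higher from compound 1 to compound 4 (the limit leaves the size open). Compound 4 is estimated at 100000 nM, in the range 30000 nM to 300000 nM.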

Compound 4, half-maximal inhibitory concentration: > 100000 nM
Compound 4 was reported as a limit (the forecaster's own chance of this, stated with the estimate: 65%); the middle value lies on the limit itself.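

Compound 1 and compound 4 both give only limits, not numbers, so no step can be read between them, and the series stays at its ceiling: the limit of > 100000 nM in this assay, at which 3 of the 4 values shown sit.

The compounds shown leave open whether benzyl to methyl changes the read-out at all on the core of compound 1.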